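Swapping Bromo for Methoxy on the Shared Core

The source may report more compounds than this note shows. Statements on the series, on what has been measured and on what is new or still open speak of the compounds shown alone.

Measured so far:
compound 1, `COc1cc(/C(Cl)=C/C=C(\C#N)C(=O)c2c[nH]c3ccc(Br)cc23)cc(OC)c1OC`, 26.3%
compound 2, `N#C/C(=C\C=C(/Cl)c1ccc(Br)cc1)C(=O)c1c[nH]c2ccc(Br)cc12`, 15.8%

Of the compounds shown here, two have been measured in a functional assay for inhibition, with a stated time of 30 min, tested at 1 mM; a higher number here means more inhibition at the concentration tested (going by the name of the read-out), a lower number less inhibition. Compound 1 has the structure `COc1cc(/C(Cl)=C/C=C(\C#N)C(=O)c2c[nH]c3ccc(Br)cc23)cc(OC)c1OC` and in this assay compound 1 gives 26.3%. Compound 2 has the structure `N#C/C(=C\C=C(/Cl)c1ccc(Br)cc1)C(=O)c1c[nH]c2ccc(Br)cc12` and in this assay compound 2 gives 15.8%. Of these two numbers, compound 2 holds the lowest; the nearest is compound 1, whose figure lies higher by a margin beyond the scatter. Compounds 1 and 2 differ from each other at more than one place, so no single structural step can be read from their pair.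

Compound 3, with the structure `COc1ccc2[nH]cc(C(=O)/C(C#N)=C/C=C(\Cl)c3ccc(Br)cc3)c2c1`, has not been measured yet. It differs from compound 2 by one change: methoxy in place of bromo on an aromatic carbon. For the measured compounds named here, no measured pair shares this change, so there is nothing to set its size by. The step from compound 2 to compound 3 is therefore expected to be a number 2.2 percentage points higher from compound 2 to compound 3 (within the scatter), that is, no change beyond the scatter. Compound 3 is estimated at 18% in this assay, with a range from 5% to 35%.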

Compound 3, a percentage reported as inhibition, at one concentration (the size of the read-out at that concentration, not a potency): 40.8%
The estimate for compound 3 lay 22.8 percentage points below the measured number; measured number above the stated range.
By their numbers in this assay, from the lowest: compound 2; then compound 1; then compound 3.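

In this assay, for the compounds shown here, methoxy in place of bromo on an aromatic carbon of the fused system of two rings gives a number 25 percentage points higher from compound 2 to compound 3 (beyond the scatter), the first step in this set that can be tied to a single place in the structure. This shows that the group at this position can, with nothing else altered, move the inhibition read at this one concentration by more than the usual scatter, something the earlier pair could not show, as compounds 1 and 2 differ at more than one place. Nothing available explains the size or the direction of this step, so it stands as an observation only.

As far as these compounds go, this change is seen only once, on the background of compound 2, so it remains open whether the same swap would raise inhibition with the other end of the molecule as it stands in compound 1. From the compounds shown here alone, it is also open whether the rise is particular to methoxy or would also appear with an amine, a longer ethoxy chain or a plain hydrogen at the same carbon.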